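A pyridyl ring in place of a chlorophenyl

This account rests on a few compounds, and the source may have more. Where it says the series, first, only, none or still open, it means among the compounds named here.

compound 1, `CC1=C(/C=C/C(=O)/C=C/c2ccc(Cl)cc2)C(C)(C)CCC1` — 90600 nM
compound 2, `CC1=C(/C=C/C(=O)/C=C/c2ccc(C)cc2)C(C)(C)CCC1` — 44100 nM
compound 3, `CC1=C(/C=C/C(=O)/C=C/c2ccccc2Cl)C(C)(C)CCC1` — 54200 nM

The three measured compounds share one core and differ only in the aromatic ring on the double-bonded chain carbon bound to a double-bonded chain carbon. In a functional assay on Hep cells (Homo sapiens) for cytotoxicity, read by sulforhodamine B assay, with a stated time of 48 h (a lower number here means a stronger inhibitor, a higher number a weaker inhibitor), compound 3 gives 54200 nM, the second highest of the three numbers. Both of its neighbours sit close: a 1.2-fold higher number from compound 2 to compound 3 (0.09 log units; within the scatter) and a 1.7-fold lower number from compound 1 to compound 3 (0.22 log units; within the scatter). Going by the values given here, the only step that goes beyond the scatter, a 2.1-fold lower number from compound 1 to compound 2 (0.31 log units; beyond the scatter), changes a substituent on the ring rather than the ring itself.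

Compound 4, `CC1=C(/C=C/C(=O)/C=C/c2cccnc2)C(C)(C)CCC1`, differs from compound 3 in that (pyridin-3-yl in place of 2-chlorophenyl on a double-bonded chain carbon bound to a double-bonded chain carbon). Among the compounds with values here, the steps that bear on this exchange are the two in which the aromatic ring was swapped at the same place, and both stayed within the scatter. Within the data shown here, no measured step exchanges a carbon-only ring for one with a nitrogen, so the expectation rests only on how little the ring swaps mattered so far. The step is therefore expected to be a 1.1-fold higher number from compound 3 to compound 4 (0.04 log units; within the scatter), not beyond the scatter in either direction. Compound 4 is expected to give about 60000 nM, within a range from 25000 nM to 150000 nM.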

Compound 4, half-maximal inhibitory concentration: 45600 nM
For compound 4 the middle estimate is 1.3-fold (0.12 log units) above the measured one; low and high end bracket the measured number.
By their numbers in this assay, from the lowest: compounds 2, 4, 3 and 1 (each within the scatter of the next, the first and the last beyond it).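

Going by these compounds alone, with pyridin-3-yl in place of 2-chlorophenyl on a double-bonded chain carbon bound to a double-bonded chain carbon, a ring with a hetero atom and a hydrogen-bond acceptor enters this place for the first time, and this assay shows a 1.2-fold lower number from compound 3 to compound 4 (0.08 log units; within the scatter). Within the data shown here, the other two new steps, a 1.0-fold higher number from compound 2 to compound 4 (0.01 log units; within the scatter) and a 2.0-fold lower number from compound 1 to compound 4 (0.30 log units; within the scatter), also stay within the scatter, so compound 4 cannot be told apart from any of the three carbon-only rings, although those rings include the one pair separated by a 2.1-fold lower number from compound 1 to compound 2 (0.31 log units; beyond the scatter). Nothing measured here explains why the nitrogen left the number so little changed.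

The compounds shown leave open whether pyridin-2-yl or pyridin-4-yl would read like pyridin-3-yl. They also leave open whether a phenyl ring carrying an amine or a carboxylic acid would produce a step beyond the scatter.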